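This account rests on a few compounds, and the source may have more. Where it says the series, first, only, none or still open, it means among the compounds named here.

Measured so far in a physicochemical assay for solubility, using the shake flask method, in simulated intestinal fluid, measured as kinetic solubility, with a stated time of 2 h, at 25 degrees C, at pH 6.5; a higher number here means a more soluble compound, a lower number a less soluble compound:
- Compound 1 `Cc1nc(C#N)c(N)c2c1C(=O)N(Cc1ccccc1)C2=O`: < 5000 nM (a limit)
- Compound 2 `COC(=O)c1nc(C)c2c(c1N)C(=O)N(Cc1ccccc1)C2=O`: 7400 nM
- Compound 3 `Cc1noc(-c2nc(C)c3c(c2N)C(=O)N(Cc2ccc(-n4cccn4)cc2)C3=O)n1`: < 5000 nM (a limit)

Compound 3 sits at < 5000 nM, which is a limit of the assay and not a number. The data also show (the limit of < 5000 nM in this assay, at which 2 of the 3 values shown sit).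

Compound 4 `Cc1noc(-c2nc(C)c3c(c2N)C(=O)N(Cc2ccc(Br)cc2)C3=O)n1` has bromo in place of 1H-pyrazol-1-yl on an aromatic carbon.

Among the measured compounds shown here, the only measured step, an at least 1.4-fold higher number from compound 1 to compound 2 (0.17 log units; that floor lies within the scatter), lies at another place on the molecule. It therefore gives little guidance here, and no step beyond the scatter is expected in this assay. The expected change is a step that the limit leaves unreadable from compound 3 to compound 4. For compound 4 the estimate is 3500 nM, with an expected range of 1200 nM to 8000 nM.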

Compound 4, solubility: < 5000 nM
Compound 4 ended at the assay's limit; the forecaster's own chance of this, stated with the estimate: 70%; the middle value lies beyond the limit too.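

Compound 3 and compound 4 both end at a limit of this assay and not at a number, so no step can be read between them: the limit of < 5000 nM in this assay, at which 3 of the 4 values shown sit.

The compounds shown leave open whether bromo or 1H-pyrazol-1-yl gives the higher number in this assay, and by how much.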